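The compounds below may be only part of what the source reports. "The series", "measured", "known", "first", "only" and "open" are said of these compounds alone.

Working notes. Compound 2 `CC(COc1cccc2ccccc12)CN1CCC(Cc2ccccc2)CC1` gives 72 nM in an assay on CHO-K1 cells for binding affinity to D(4) dopamine receptor (Homo sapiens); a higher number here means a weaker inhibitor, a lower number a stronger inhibitor; compound 1 `c1ccc(CC2CCN(CCCOc3cccc4ccccc34)CC2)cc1` gives 50 nM, and the step of a 1.4-fold higher number from compound 1 to compound 2 (0.16 log units; within the scatter) is within the scatter, so the two numbers shown stand together. Compound 3 `COC(COc1cccc2ccccc12)CN1CCC(Cc2ccccc2)CC1` differs from compound 2 by methoxy in place of methyl on a saturated chain carbon bound to two saturated chain carbons. Among the measured compounds shown here, only the step from compound 1 to compound 2 touches this chain carbon, and it stayed within the scatter; no measured pair carries a methoxy there. The step from compound 2 to compound 3 is therefore expected to be a 1.3-fold higher number from compound 2 to compound 3 (0.10 log units; within the scatter), with low confidence. Compound 3 is estimated at 90 nM, in a range from 30 nM to 270 nM.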

Compound 3, inhibition constant: 45 nM
Estimate against measurement, compound 3: 2.0-fold (0.30 log units) above; the range from low to high includes it.
By their numbers in this assay, from the lowest: compounds 3, 1 and 2 (each within the scatter of the next).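

In this assay, this saturated chain carbon now has a third substituent, an oxygen-bearing one, and the numbers still stand together: a 1.6-fold lower number from compound 2 to compound 3 (0.20 log units; within the scatter), and a 1.1-fold lower number from compound 1 to compound 3 (0.05 log units; within the scatter). Hydrogen, methyl and methoxy at this place cannot be told apart, so the hydrogen-bond acceptor that enters with methoxy brings no step beyond the scatter. No supporting evidence bears on this result. From the compounds shown here alone, whether an amine, a carboxylic acid or a longer chain such as ethoxy on this carbon would give a step beyond the scatter remains open.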